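Replacing methyl with phenyl on the ketone aryl ring

The source may hold more compounds than are shown below. What is called first, only, known or untested is meant among the compounds shown, and "the series" means these compounds.

Compound 1 `COc1cc(-c2nnc3n2NC(c2ccco2)C(C(=O)c2ccc(Br)cc2)S3)cc(OC)c1OC`: in a functional assay on HepG2 cells (Homo sapiens) for cytotoxicity, read by MTT assay, with a stated time of 48 h (on this read-out higher numbers stand for weaker inhibition and lower numbers for stronger inhibition), compound 1 gives > 100000 nM, which is a limit of the assay and not a number.
Compound 2 `COc1cc(-c2nnc3n2NC(c2ccco2)C(C(=O)C2CC2)S3)cc(OC)c1OC`: compound 2 gives > 100000 nM, again a limit of the assay.
Compound 3 `COc1cc(-c2nnc3n2NC(c2ccco2)C(C(=O)c2ccc(C)cc2)S3)cc(OC)c1OC`: compound 3 gives 17400 nM.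

Among the compounds with values here, of the three compounds measured, compound 3 is the only one with an actual number; the other two sit at the limit (the limit of > 100000 nM in this assay, at which 2 of the 3 values shown sit). The step from compound 1 to compound 3 is an at least 5.7-fold lower number from compound 1 to compound 3 (0.75 log units; beyond the scatter), and the step from compound 2 to compound 3 is an at least 5.7-fold lower number from compound 2 to compound 3 (0.75 log units; beyond the scatter). The step that the two limits leave unreadable from compound 1 to compound 2 cannot be read, since both ends are limits.

Compound 4 `COc1cc(-c2nnc3n2NC(c2ccco2)C(C(=O)c2ccc(-c4ccccc4)cc2)S3)cc(OC)c1OC` differs from compound 3 by phenyl in place of methyl on an aromatic carbon. Within the data shown here, no measured step adds a ring at this place, so the two readable steps bear on it only by showing that changing the group on the ketone aryl ring can move the number beyond the scatter. With so little to lean on, compound 4 is expected to give roughly 30000 nM, between 8000 nM and 100000 nM, a change of a 1.7-fold higher number from compound 3 to compound 4 (0.24 log units; within the scatter) that is uncertain in direction and may well end at a limit.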

Compound 4, half-maximal inhibitory concentration: > 100000 nM
Compound 4 was reported as a limit; the forecaster's own chance of this, stated with the estimate: 35%; middle value at least 3.3-fold (0.52 log units) away from the limit.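

This step shows that the group at the far end of the ketone aryl ring can do more than shift the reading slightly: in this assay, phenyl in place of methyl on this aromatic carbon gives an at least 5.7-fold higher number from compound 3 to compound 4 (0.75 log units; beyond the scatter). Compound 4 gives a limit of the assay and not a number, and it joins most of the set there: the limit of > 100000 nM in this assay, at which 3 of the 4 values shown sit. Of the three groups shown at this place, bromo, methyl and phenyl, only methyl gives an actual number, although the steps from compound 1 to compound 4 and from compound 2 to compound 4 cannot be read, since both ends of each are limits.

On these data alone, it remains open whether another small group at this place, such as methoxy, an amine or a plain hydrogen, would give a lower number than methyl does, or a higher one. As far as these compounds go, it is equally open whether a longer chain such as ethyl or propyl would keep a readable number in this assay, or whether methyl stands alone among the groups at this place.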